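Changing the Amide Side Chain of Compound 2

This account rests on a few compounds, and the source may have more. Where it says the series, first, only, none or still open, it means among the compounds named here.

In a functional assay on PC-3 cells (Homo sapiens) for antiproliferative activity, read by MTT assay, with a stated time of 24 h (a lower number here means a stronger inhibitor, a higher number a weaker inhibitor), compound 1 `CCn1c(C(=O)N[C@@H](CO)CCO)ccc1C(CC)(CC)c1ccc(OCS(=O)(=O)c2ccccc2)c(C)c1` gives 14100 nM and compound 2 `CCn1c(C(=O)N[C@H](C)C(=O)O)ccc1C(CC)(CC)c1ccc(OCS(=O)(=O)c2ccccc2)c(C)c1` gives 20100 nM, so these two values lie within the usual scatter of each other. Compound 3 `CCn1c(C(=O)N[C@H](C(=O)O)C(C)C)ccc1C(CC)(CC)c1ccc(OCS(=O)(=O)c2ccccc2)c(C)c1` carries 1-carboxy-2-methylpropyl in place of 1-carboxyethyl on an amide-type nitrogen. Going by the values given here, only one measured step bears on this place, a 1.4-fold higher number from compound 1 to compound 2 (0.15 log units; within the scatter), and it stays within the scatter. On that single step, no change beyond the scatter is expected, and the estimated move is a 1.1-fold lower number from compound 2 to compound 3 (0.05 log units; within the scatter). The expected value for compound 3 is 18000 nM, with an estimated range from 8000 nM to 40000 nM.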

Compound 3, half-maximal inhibitory concentration: 3650 nM
The estimate for compound 3 lay 4.9-fold (0.69 log units) above the measured number, and the stated range ends above it.
By their numbers in this assay, from the lowest: compound 3; then compounds 1 and 2 (each within the scatter of the next).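

In this assay, the group on the amide-type nitrogen can shift the number beyond the scatter, which the earlier pair did not show. Replacing 1-carboxyethyl with 1-carboxy-2-methylpropyl gives a 5.5-fold lower number from compound 2 to compound 3 (0.74 log units; beyond the scatter), and replacing 3-hydroxy-1-(hydroxymethyl)propyl with it gives a 3.9-fold lower number from compound 1 to compound 3 (0.59 log units; beyond the scatter). No supporting data explain why the number falls.

From the compounds shown here alone, whether a longer carbon chain or a phenyl ring on this carbon would lower the number further remains open. So does whether a methyl ester or primary amide could replace the carboxylic acid.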